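Carboxy in place of cyano: compound 3 to compound 4

The compounds below may be only part of what the source reports. "The series", "measured", "known", "first", "only" and "open" are said of these compounds alone.

In a functional assay on MKN-45 cells (Homo sapiens) for antiproliferative activity (a higher number here means a weaker inhibitor, a lower number a stronger inhibitor), compound 3 (`COc1ccc(S(=O)(=O)N2CCc3cccc(Nc4ccc(C#N)cc4)c32)cc1`) gives 92 nM and compound 2 (`COc1ccc(S(=O)(=O)N2CCc3cccc(Nc4ccc([N+](=O)[O-])cc4)c32)cc1`) gives 107 nM, within the scatter of each other, while compound 1 (`COc1ccc(S(=O)(=O)N2CCc3cccc(Nc4ccc(F)cc4)c32)cc1`) gives 563 nM. The next structure, compound 4 (`COc1ccc(S(=O)(=O)N2CCc3cccc(Nc4ccc(C(=O)O)cc4)c32)cc1`), carries carboxy in place of cyano on an aromatic carbon, para to a large group: carboxy in place of cyano on an aromatic carbon. Three measured steps at this place bear on it: a 6.1-fold lower number from compound 1 to compound 3 (0.79 log units; beyond the scatter) and a 5.3-fold lower number from compound 1 to compound 2 (0.72 log units; beyond the scatter), both modest, and a 1.2-fold lower number from compound 2 to compound 3 (0.07 log units; within the scatter), within the scatter. Among the compounds with values here, no measured compound carries carboxy, so the direction is a judgement and the range is wide. The estimated change is an 8.7-fold higher number from compound 3 to compound 4 (0.94 log units; beyond the scatter), a modest step towards a higher number in this assay. For compound 4 the expected value is 800 nM, with an estimated range of 150 nM to 5000 nM.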

Compound 4, half-maximal inhibitory concentration: 1390 nM
Compound 4: middle estimate off by 1.7-fold (0.24 log units), on the low side; measured number inside the range.
By their numbers in this assay, from the lowest: compounds 3 and 2 (each within the scatter of the next); then compound 1; then compound 4.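

In this assay the steps of a 15-fold higher number from compound 3 to compound 4 (1.18 log units; beyond the scatter) and a 13-fold higher number from compound 2 to compound 4 (1.11 log units; beyond the scatter) are both large, so the low numbers shared by cyano and nitro at this place do not carry over to carboxy. Carboxy also ends up on the weaker side of fluoro, with a 2.5-fold higher number from compound 1 to compound 4 (0.39 log units; beyond the scatter) beyond the scatter, which gives this position its first group with a higher number than compound 1. Open, going by these compounds, is whether a methyl ester or a primary amide in place of carboxy would return the number towards those of cyano and nitro. Nothing shown here explains the rise.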